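Ethylamino Gives Way to Dimethylamino

This account rests on a few compounds, and the source may have more. Where it says the series, first, only, none or still open, it means among the compounds named here.

Among the compounds with values here, in a functional assay on HeLa cells (Homo sapiens) for antiproliferative activity, read by MTT assay, with a stated time of 48 h (a higher number here means a weaker inhibitor, a lower number a stronger inhibitor), compound 1 `COc1ccc(C(=O)c2ccc(OC)c3c2C=CC(C)(C)O3)c(NC(=O)CBr)c1` gives 3680 nM and compound 2 `CCNCC(=O)Nc1cc(OC)ccc1C(=O)c1ccc(OC)c2c1C=CC(C)(C)O2` gives 4270 nM, so compound 2 sits level with its only measured neighbour. Compound 3 `COc1ccc(C(=O)c2ccc(OC)c3c2C=CC(C)(C)O3)c(NC(=O)CN(C)C)c1` changes one group of compound 2, with dimethylamino in place of ethylamino on a saturated chain carbon bound to a carbonyl carbon. Within the data shown here, only one measured step touches this place, a 1.2-fold higher number from compound 1 to compound 2 (0.06 log units; within the scatter), where bromo became ethylamino and the number stayed within the scatter. That step suggests little sensitivity here, though it is thin evidence. The expected step is a 1.1-fold lower number from compound 2 to compound 3 (0.03 log units; within the scatter), with no move beyond the scatter in either direction. For compound 3 the estimated value is 4000 nM, with a range from 1800 nM to 9000 nM.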

Compound 3, half-maximal inhibitory concentration: 3620 nM
Compound 3: middle estimate off by 1.1-fold (0.04 log units), on the high side; measured number inside the range.
By their numbers in this assay, from the lowest: compounds 3, 1 and 2 (each within the scatter of the next).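

In this assay the hydrogen-bond donor count of the group on this carbon drops from 1 to 0, with a 1.2-fold lower number from compound 2 to compound 3 (0.07 log units; within the scatter) as the result, so losing that donor leaves the number level. Bromo and dimethylamino also read level, with a 1.0-fold lower number from compound 1 to compound 3 (0.01 log units; within the scatter) as their step, so the three groups on this saturated chain carbon bound to a carbonyl carbon cannot be told apart. Nothing measured explains this flat reading. As far as these compounds go, whether a carboxylic acid or a piperidine ring here would move the number beyond the scatter stays open.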